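The compounds below may be only part of what the source reports. "The series", "measured", "known", "first", "only" and "open" are said of these compounds alone.

Among the measured compounds shown here, compound 2 `C/C=C1/[C@H](O[C@@H]2O[C@H](CO)[C@@H](O)[C@H](O)[C@H]2O)OC=C(C(=O)OC)[C@H]1CC(=O)OCCC1CCCCC1` is the one compound with an actual number here: in a functional assay on SK-BR-3 cells (Homo sapiens) for antiproliferative activity, read by MTT assay, with a stated time of 72 h (on this read-out lower numbers stand for stronger inhibition and higher numbers for weaker inhibition), compound 2 gives 2000 nM. Compound 1 `C=C(C)CCOC(=O)C[C@@H]1C(C(=O)OC)=CO[C@@H](O[C@@H]2O[C@H](COC(C)=O)[C@@H](OC(C)=O)[C@H](OC(C)=O)[C@H]2OC(C)=O)/C1=C/C` is reported only as a limit of the assay, where compound 1 gives > 15000 nM, a point recorded as the limit of > 15000 nM in this assay, at which 1 of the 2 values shown sits. Compound 3 `C/C=C1/[C@H](O[C@@H]2O[C@H](CO)[C@@H](O)[C@H](O)[C@H]2O)OC=C(C(=O)OC)[C@H]1CC(=O)OCCc1ccccc1` has not been measured; it differs from compound 2 by phenyl in place of cyclohexyl on a saturated chain carbon, two bonds along the chain from an oxygen next to a carbonyl group. No measured step joins any two compounds here, so this change has no precedent among these numbers. The step of no change at the digits printed from compound 2 to compound 3 (within the scatter) is expected to stay within the usual scatter. Compound 3 is therefore estimated at 2000 nM, with a range from 700 nM to 6000 nM.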

Compound 3, half-maximal inhibitory concentration: 11000 nM
Compound 3: middle estimate off by 5.5-fold (0.74 log units), on the low side; measured number above the stated range.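

Phenyl in place of cyclohexyl is not a neutral swap in this assay: it gives a 5.5-fold higher number from compound 2 to compound 3 (0.74 log units; beyond the scatter), even though the two rings have the same count of heavy atoms. This first measured step shows that this position responds to the kind of ring it carries. Compound 1 alone stands at a limit of the assay, so this step joins two real numbers: the limit of > 15000 nM in this assay, at which 1 of the 3 values shown sits.

From the compounds shown here alone, whether an amine, a carboxylic acid or a longer chain here would do better stays open. A single step also cannot say why compound 3 is weaker.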